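The compounds below may be only part of what the source reports. "The series", "measured", "known", "first", "only" and "open" are said of these compounds alone.

Measured compounds:
compound 1, `CC(c1cc2cccnc2cc1F)n1cnc2ncc(-c3cnn(C)c3)nc21`, 31.3 nM;
compound 2, `Cc1c(C(C)n2cnc3ncc(-c4cnn(C)c4)nc32)ccc2ncccc12`, 206 nM;
compound 3, `CC(c1cc2cccnc2cc1F)n1cnc2ncc(-c3cn[nH]c3)nc21`, 187 nM.

The three measured compounds were tested in a functional assay on NCI-H1993 cells (Homo sapiens) for inhibition, read by CCK-8 assay, with a stated time of 72 h; a lower number here means a stronger inhibitor, a higher number a weaker inhibitor. Compound 1 gives 31.3 nM and compound 3 gives 187 nM. Compound 3 differs from compound 1 in one place, (hydrogen in place of methyl on an aromatic nitrogen), and this change produced a 6.0-fold higher number from compound 1 to compound 3 (0.78 log units; beyond the scatter). Compound 2 gives 206 nM; it has the highest number of the three, and its value and that of compound 3 lie within the usual scatter of each other, so no order between those two can be read. The difference between the core of compound 1 and the core of compound 2 is not broken down here.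

Compound 4, `Cc1c(C(C)n2cnc3ncc(-c4cn[nH]c4)nc32)ccc2ncccc12`, has not yet been measured. It stands to compound 2 as compound 3 stands to compound 1: the same change, (hydrogen in place of methyl on an aromatic nitrogen), made on the core of compound 2. Within the data shown here, the one earlier instance of this change, from compound 1 to compound 3, raised the number clearly, so on that precedent compound 4 is expected to give a higher number than compound 2, with a step of roughly a 5.3-fold higher number from compound 2 to compound 4 (0.73 log units; beyond the scatter) in this assay. Among the measured compounds shown here, that expectation rests only on the single step of a 6.0-fold higher number from compound 1 to compound 3 (0.78 log units; beyond the scatter), and whether the change acts alike on the core of compound 2 is not known from these data. Compound 4 is therefore estimated to give about 1100 nM in this assay, plausibly between 400 nM and 3000 nM.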

Compound 4, half-maximal inhibitory concentration: 599 nM
Compound 4: the middle estimate sits 1.8-fold (0.26 log units) above what was measured; the range from low to high includes it.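

In this assay, the change from 1-methyl-1H-pyrazol-4-yl to 1H-pyrazol-4-yl, made this time on the second of the two cores, gave a 2.9-fold higher number from compound 2 to compound 4 (0.46 log units; beyond the scatter). Set beside the earlier instance, the new step runs in the same direction, and the gap between the two sizes does not exceed what repeated measurements would produce: the same change on two cores in this assay, a 6.0-fold higher number (0.78 log units; beyond the scatter) from compound 1 to compound 3 and a 2.9-fold higher number (0.46 log units; beyond the scatter) from compound 2 to compound 4, 2.1-fold (0.31 log units) apart, within the scatter of two such steps. Within this small series, the loss from replacing the methyl on the aromatic nitrogen with hydrogen therefore carried over from one core to the other, and the two steps cannot be said to differ in size, although this does not show that they are equal, that the same step would appear on any further core, or what lies behind the rise.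

The compounds shown have only methyl or hydrogen on that aromatic nitrogen, so they leave open how an ethyl group, a longer chain, or a chain ending in an amine or a carboxylic acid would behave there. They also leave open whether any such group would give a lower number than methyl on either core.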